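The source may hold more compounds than are shown below. What is called first, only, known or untested is meant among the compounds shown, and "the series" means these compounds.

Series notes from an assay on isolated protein for inhibition of Apoptosis regulator Bcl-2 (Homo sapiens), read by fluorescence polarization, with stated times of 5 min and 10 min; a lower number here means a stronger inhibitor, a higher number a weaker inhibitor. Among the measured compounds shown here, compound 2 `CONC(=O)[C@@H]1CC=C(CCC=C(C)C)C[C@H]1c1ccccc1` gives 2700 nM in this assay and is the only compound with a number rather than a limit. Compound 1 `CC1(C)CCCC2=C1C[C@@H](C(=O)O)[C@H](c1ccccc1)C2` reaches only the assay limit of > 23000 nM. Compound 3 `CON(C)C(=O)[C@@H]1CC2=C(CCCC2(C)C)C[C@H]1c1ccccc1` likewise reaches only the assay limit of > 23000 nM. For the measured compounds named here, the one measured step, a step that the two limits leave unreadable from compound 1 to compound 3, has both ends sitting at the limit of > 23000 nM in this assay, at which 2 of the 3 values shown sit, so its size is not readable and it offers no calibration for a change on the carbonyl carbon. Compound 4 `CC(C)=CCCC1=CC[C@@H](C(=O)N(C)O)[C@H](c2ccccc2)C1` differs from compound 2 by hydroxy(methyl)amino in place of methoxyamino on a carbonyl carbon. Going by the values given here, no measured step bears directly on this change; the step from compound 1 to compound 3 touches the same carbonyl carbon but is unreadable, and compound 2 stands alone with a number. With nothing to point either way, compound 4 is expected to stay close to compound 2, the expected step being a 1.3-fold higher number from compound 2 to compound 4 (0.11 log units; within the scatter), with a wide range allowed. Compound 4 is estimated at 3500 nM, within 1200 nM to 12000 nM.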

Compound 4, inhibition constant: 2300 nM
For compound 4 the middle estimate is 1.5-fold (0.18 log units) above the measured one, and the stated range covers the measured number.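

In this assay, hydroxy(methyl)amino in place of methoxyamino on a carbonyl carbon gives a 1.2-fold lower number from compound 2 to compound 4 (0.07 log units; within the scatter). Among the compounds shown here, this is the first readable step at this position, and it shows that, with the shared core held fixed, these two groups of the same atoms cannot be told apart in this read-out. The earlier step from compound 1 to compound 3 at the same carbonyl carbon still cannot be read, its two ends being limits of the assay: the limit of > 23000 nM in this assay, at which 2 of the 4 values shown sit.

Open, as far as these compounds go, is whether a larger group on the carbonyl carbon, such as ethoxyamino or dimethylamino, would stay level with compound 2 and compound 4. Also open, from the compounds shown here alone, is whether a carboxylic acid, present in compound 1 on a different core, would read any differently on the core of compound 2.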